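Indole Carboxamide Piperazinones: Half-Life Before a Larger Amine

This account rests on a few compounds, and the source may have more. Where it says the series, first, only, none or still open, it means among the compounds named here.

Three compounds sharing an indole carboxamide attached to a piperazinone core have been measured in an ADME assay on microsomes from liver (Homo sapiens) for metabolic stability, with a stated time of 30 min, tested at 1 uM; a higher number here means that the compound lasts longer, a lower number that the compound disappears faster. Compound 1 `O=C(c1cc2cc(C3CC3)ccc2[nH]1)N1CC(=O)N(Cc2ccccc2)[C@@H](CN2CCC(F)CC2)C1` gives 0.383 h. Compound 2 `COc1ccc2[nH]c(C(=O)N3CC(=O)N(Cc4ccc[nH]4)[C@@H](Cc4ccccc4)C3)cc2c1` gives 0.267 h in this assay. Compound 3 `COc1ccc2[nH]c(C(=O)N3CC(=O)N(Cc4ccccc4)[C@@H](COC(C)(C)C)C3)cc2c1` gives 0.278 h in this assay, which places it second highest of the three numbers; its nearest neighbour is compound 2, and its furthest is compound 1, and both of those gaps lie within the usual scatter of repeated measurements, so nothing among the three can be called more or less stable than another.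

The next compound, compound 4 `COc1ccc2[nH]c(C(=O)N3CC(=O)N(Cc4ccccc4)[C@@H](CN4CCCc5ccccc54)C3)cc2c1`, differs from compound 3 in one place: 1,2,3,4-tetrahydroquinolin-1-yl in place of tert-butoxy on a saturated chain carbon bound to a saturated ring carbon. Among the compounds with values here, no pair of measured compounds shows this kind of exchange, so there is no directly comparable step to lean on. With only the three measured values, which all sit close together, the expectation for the move from compound 3 to compound 4 is a small step downward in half-life, estimated as a 1.3-fold lower number from compound 3 to compound 4 (0.10 log units; within the scatter), which may well remain inside the scatter. For compound 4 the half-life in this assay is therefore estimated at 0.22 h, with a range expected between 0.09 h and 0.55 h.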

Compound 4, half-life: 0.183 h
Compound 4: middle estimate off by 1.2-fold (0.08 log units), on the high side; measured number inside the range.
By their numbers in this assay, from the lowest: compounds 4, 2, 3 and 1 (each within the scatter of the next, the first and the last beyond it).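

At the position on a saturated chain carbon bound to a saturated ring carbon, the exchange of tert-butoxy, with 5 heavy atoms and no ring, for 1,2,3,4-tetrahydroquinolin-1-yl, with 10 heavy atoms in a non-aromatic and an aromatic ring, gives a 1.5-fold lower number from compound 3 to compound 4 (0.18 log units; within the scatter) in this assay. Within the data shown here, this is the first step that changes one place only, and it shows that a group with more heavy atoms, bringing a ring nitrogen in place of the ether oxygen, can stand here without a difference in half-life that can be told from repeated measurement. Nothing available bears on what lies behind this step, which therefore stands as an observation alone.

The compounds shown leave open whether any group at this place would give a step beyond the scatter, for instance a small open-chain amine such as dimethylamino, a morpholine or a carboxylic acid. They also leave open whether the same exchange would read alike with a different group on the indole or on the ring nitrogen of the shared core.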